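The compounds below may be only part of what the source reports. "The series", "measured", "known", "first", "only" and "open" are said of these compounds alone.

In a functional assay on HCT-116 cells (Homo sapiens) for antiproliferative activity, read by MTT assay, with a stated time of 72 h (a lower number here means a stronger inhibitor, a higher number a weaker inhibitor), compound 1 `Cc1ccccc1N1CCN(C(=S)SCc2ccc3nc(N)nc(N)c3c2)CC1` gives 11800 nM and compound 2 `CC(=O)c1ccc(N2CCN(C(=S)SCc3ccc4nc(N)nc(N)c4c3)CC2)cc1` gives 8260 nM on the same shared core. Among the measured compounds shown here, these are the only two numbers so far. They lie within the scatter of each other, so compound 2 cannot be separated from compound 1 on this evidence.

Compound 3 `Nc1nc(N)c2cc(CSC(=S)N3CCN(c4ccccn4)CC3)ccc2n1` brings the next change, pyridin-2-yl in place of 4-acetylphenyl on an amine nitrogen in a ring with pyridin-2-yl in place of 4-acetylphenyl on an amine nitrogen in a ring. For the measured compounds named here, the one measured step on that nitrogen is a 1.4-fold lower number from compound 1 to compound 2 (0.15 log units; within the scatter) and it also exchanged one ring-bearing group for another. Going by the values given here, that single step is thin evidence, and no compound carrying pyridin-2-yl has yet been measured. Even so, it gives no reason to expect a large shift, and it favours neither direction. The estimated 1.1-fold higher number from compound 2 to compound 3 (0.04 log units; within the scatter) is accordingly expected to stay within the scatter. For compound 3 the expected value is 9000 nM with an estimated range from 3500 nM to 22000 nM in this wider reading of a thin series.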

Compound 3, half-maximal inhibitory concentration: 5960 nM
Compound 3: the middle estimate sits 1.5-fold (0.18 log units) above what was measured; the measured number falls inside the stated range.
By their numbers in this assay, from the lowest: compounds 3, 2 and 1 (each within the scatter of the next).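

Exchanging the carbon-only aromatic ring of 4-acetylphenyl for the ring with one hetero atom in pyridin-2-yl, on the amine nitrogen of the six-membered ring, gives a 1.4-fold lower number from compound 2 to compound 3 (0.14 log units; within the scatter) in this assay and so cannot be told apart from no change, even though the acetyl carbonyl leaves with it. The comparison with 2-methylphenyl, a 2.0-fold lower number from compound 1 to compound 3 (0.30 log units; within the scatter) on the same nitrogen, is also printed as within the scatter, so the three compounds remain unseparated and this position has not yet shown any dependence on whether its aromatic ring carries a hetero atom, a methyl group or an acetyl group. Nothing measured here speaks to why these three groups read alike.

From the compounds shown here alone, all three groups place an aromatic ring directly on this nitrogen, so it stays open whether a group without such a ring, such as a plain methyl, a benzyl group or a chain ending in a carboxylic acid, would give a number beyond the scatter. Going by these compounds, it also stays open whether moving the ring nitrogen, as in pyridin-3-yl or pyridin-4-yl, would separate from compound 3 in this assay.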